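Opening the Small Ring on the Amide Side Chain

The compounds below may be only part of what the source reports. "The series", "measured", "known", "first", "only" and "open" are said of these compounds alone.

Of the compounds shown here, three built on one shared core have been tested in an assay on cells for positive allosteric modulation of Cystic fibrosis transmembrane conductance regulator variant F508del (Homo sapiens), with stated times of 10 min and 7 s, in the presence of a further agent that is not named here; a lower number here means that less compound is needed, a higher number that more compound is needed for the effect. Compound 1 `CC1(C)Cc2c(sc(NC(=O)c3nnc[nH]3)c2C(N)=O)C(C)(C)O1` gives 467 nM. Compound 2 `CC1(C)Cc2c(sc(NC(=O)c3ccn[nH]3)c2C(N)=O)C(C)(C)O1` gives 3 nM, and compound 3 `CC1(C)Cc2c(sc(NC(=O)C3(O)CC3)c2C(N)=O)C(C)(C)O1` gives 23 nM. Compound 3 thus stands second of the three numbers. Its neighbours tell the gaps: a 20-fold lower number from compound 1 to compound 3 (1.31 log units; beyond the scatter), while a 7.7-fold higher number from compound 2 to compound 3 (0.88 log units; beyond the scatter). Compound 4 `CC1(C)Cc2c(sc(NC(=O)[C@@H](O)C(C)(C)C)c2C(N)=O)C(C)(C)O1` differs from compound 3 in one place: 1-hydroxy-2,2-dimethylpropyl in place of 1-hydroxycyclopropyl on a carbonyl carbon. Within the data shown here, none of the measured steps exchanges one hydroxy-bearing carbon group for another, so the size of this move cannot be read from a neighbour; the only anchor is the value of compound 3 itself. A modest step is expected: a 1.7-fold higher number from compound 3 to compound 4 (0.24 log units; within the scatter). Compound 4 is therefore estimated at 40 nM, within 10 nM to 160 nM.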

Compound 4, half-maximal effective concentration: 2.7 nM
Beside the measured number, compound 4's estimate is 15-fold (1.17 log units) above it, and the stated range ends above it.
By their numbers in this assay, from the lowest: compounds 4 and 2 (each within the scatter of the next); then compound 3; then compound 1.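

In this assay, replacing the small ring with the open 1-hydroxy-2,2-dimethylpropyl chain, which carries one defined stereocentre, gives an 8.5-fold lower number from compound 3 to compound 4 (0.93 log units; beyond the scatter), so this position accepts a larger hydroxy-bearing group with no ring. The same chain compares with the 1H-pyrazol-5-yl group through a 1.1-fold lower number from compound 2 to compound 4 (0.05 log units; within the scatter), and with the 4H-1,2,4-triazol-3-yl group through a 170-fold lower number from compound 1 to compound 4 (2.24 log units; beyond the scatter). Nothing measured here bears on why the open chain gives the lower number.

On these data alone, whether the hydroxy group is needed remains open, as does the effect of an amine in its place. A longer chain on the same carbonyl carbon also remains untested in the compounds shown.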